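A few compounds are considered here, and "the series" means these few. Any claim that something is new, unique, unknown or untested is made for them only; others in the source may bear on it.

Of the compounds shown here, three have so far been tested in a functional assay on EL4 cells (Mus musculus) for inhibition, tested at 100 uM; on this read-out higher numbers stand for more inhibition at the one concentration tested (going by the name of the read-out) and lower numbers for less inhibition. Compound 1 `OC[C@H]1O[C@@H](n2cnc3c(NCc4ccccc4)nccc32)C[C@@H]1O` is the only one of them that gives a number: in this assay compound 1 gives 8%. Compound 2 `[N-]=[N+]=Nc1[nH]ccc2ncnc1-2` reaches only a limit of the assay, < 5%. Compound 3 `[O-][n+]1ccc2c(c1)ncn2[C@H]1C[C@H](O)[C@@H](CO)O1` likewise sits at a limit of the assay, < 5%. Compound 1 thus stands alone with a number, and that number is small; what is known of the other two is the limit of < 5% in this assay, at which 2 of the 3 values shown sit. Within the data shown here, no two of the measured compounds differ from each other in one place only, so there is no measured step to go by.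

Compound 4 `OC[C@H]1O[C@@H](n2cnc3c(S)nccc32)C[C@@H]1O` has not yet been measured. It differs from compound 1 in a single place: sulfanyl in place of benzylamino on an aromatic carbon. With no measured step to lean on, and with the one number shown lying close to the limit at which the other two values sit, no step beyond the scatter is expected in this assay in either direction. Compound 4 is therefore expected to give about 6% in this assay, with a range from 0% to 16%. The expected step is a number 2 percentage points lower from compound 1 to compound 4 (within the scatter), which lies within the scatter. There is also a fair chance that compound 4 will be reported only as a limit rather than as a number.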

Compound 4, a percentage reported as inhibition, at one concentration (the size of the read-out at that concentration, not a potency): < 5%
Compound 4: only a limit was reported (the forecaster's own chance of this, stated with the estimate: 45%); middle value at least 1 percentage points away from the limit.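

In this assay, the exchange of benzylamino for sulfanyl on an aromatic carbon next to the ring nitrogen gives a number at least 3 percentage points lower from compound 1 to compound 4 (that floor lies within the scatter). Among these compounds, this is the first measured change at this place, and it shows that the whole benzylamino group, with its six-membered aromatic ring of carbon only, can be replaced by a single sulfur-bearing group without a step that can be read as beyond the scatter, so the benzylamino group cannot be credited with any real inhibition. The read-out also leaves little room to tell such compounds apart, since most of them now rest at the same limit of the assay: the limit of < 5% in this assay, at which 3 of the 4 values shown sit.

What the compounds shown leave open is whether any group at this place can lift the shared core clear of that limit, for instance a simple amine, a longer alkyl chain or a carboxylic acid. With readings at a single concentration, they also leave open whether this place matters at all for inhibition in this assay.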